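Compound 4: nitro in place of trifluoromethyl

This account rests on a few compounds, and the source may have more. Where it says the series, first, only, none or still open, it means among the compounds named here.

In a functional assay on PC-3 cells (Homo sapiens) for antiproliferative activity, read by sulforhodamine B assay, with a stated time of 48 h (a higher number here means a weaker inhibitor, a lower number a stronger inhibitor), compound 3 (`Cc1cc2c(C(C)C)ccc(C)c2cc1OC(=O)c1ccc(C(F)(F)F)cc1`) gives 34000 nM. This lies within the scatter of compound 2 (`CC1=CC[C@H](C(C)C)c2cc(C)c(OC(=O)c3ccc([N+](=O)[O-])cc3)cc21`) at 42500 nM, while compound 1 (`CC1=CC[C@H](C(C)C)c2cc(C)c(OC(=O)Nc3ccccc3)cc21`) stands apart with a lower number, 7930 nM.

Compound 4 (`Cc1cc2c(C(C)C)ccc(C)c2cc1OC(=O)c1ccc([N+](=O)[O-])cc1`) differs from compound 3 in one place: nitro in place of trifluoromethyl on an aromatic carbon.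

Among the measured compounds shown here, only one measured step is available, a 5.4-fold higher number from compound 1 to compound 2 (0.73 log units; beyond the scatter). It is modest, but it exchanges other groups on the core of compound 1, so it does not measure this swap directly. The closest guide is compound 2, which carries the nitro group and gives 42500 nM. With that value in mind, no step beyond the scatter is expected in this assay, in either direction.

The estimated step is a 1.1-fold higher number from compound 3 to compound 4 (0.02 log units; within the scatter). For compound 4 the expected value is 36000 nM, with an estimated range of 16000 nM to 75000 nM.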

Compound 4, half-maximal inhibitory concentration: 17600 nM
For compound 4 the middle estimate is 2.0-fold (0.31 log units) above the measured one, within the range that was stated.
By their numbers in this assay, from the lowest: compound 1; then compounds 4, 3 and 2 (each within the scatter of the next, the first and the last beyond it).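

In this assay, among the compounds shown here, the swap on an aromatic carbon para to a large group gives a 1.9-fold lower number from compound 3 to compound 4 (0.29 log units; within the scatter), the first direct reading of this position. Trifluoromethyl and nitro are therefore not separated here on the core of compound 3, so this exchange alone gives no measurable handle on antiproliferative activity. No measurement at hand bears on why these two groups read alike.

The compounds shown leave open whether an amine or a carboxylic acid at the same place would give a step beyond the scatter in this assay. Also open, on these data alone, is whether a 5.4-fold higher number from compound 1 to compound 2 (0.73 log units; beyond the scatter), seen on the core of compound 1, would carry over to the core of compound 3 if the anilino group stood in place of the 4-nitrophenyl group.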